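From a 2-ethylphenyl group to a 2,4-dimethylphenyl group

A few compounds are considered here, and "the series" means these few. Any claim that something is new, unique, unknown or untested is made for them only; others in the source may bear on it.

Going by the values given here, compound 2 `CCc1ccccc1-c1cc2c(cn1)ncn2-c1ccc(OC(F)F)cc1` gives 2900 nM in a functional assay on HL-60 cells (Homo sapiens) for activation, read by flow cytometry, with a stated time of 4 days (on this read-out higher numbers stand for an effect only at larger amounts of compound and lower numbers for an effect already at smaller amounts), the lowest of the two numbers known here; compound 1 `Fc1ccc(-c2cc3c(cn2)ncn3-c2ccc(OC(F)F)cc2)cc1` gives 10000 nM, and the step of a 3.4-fold lower number from compound 1 to compound 2 (0.54 log units; beyond the scatter) is modest. Compound 3 `Cc1ccc(-c2cc3c(cn2)ncn3-c2ccc(OC(F)F)cc2)c(C)c1` differs from compound 2 by 2,4-dimethylphenyl in place of 2-ethylphenyl on an aromatic carbon. Among the compounds with values here, only that one step is known, and it concerns a different change, so no strong shift is expected; the step from compound 2 to compound 3 is estimated to stay within the scatter a 1.1-fold lower number from compound 2 to compound 3 (0.03 log units; within the scatter). Compound 3 is therefore expected to give about 2700 nM, with a range from 1000 nM to 7500 nM.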

Compound 3, half-maximal effective concentration: 180 nM
For compound 3 the middle estimate is 15-fold (1.18 log units) above the measured one; measured number below the stated range.
By their numbers in this assay, from the lowest: compound 3; then compound 2; then compound 1.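

Compound 2 and compound 3 carry groups with the same count of heavy atoms and the same kind of ring, yet 2,4-dimethylphenyl in place of 2-ethylphenyl gives a 16-fold lower number from compound 2 to compound 3 (1.21 log units; beyond the scatter), so this position distinguishes sharply between two isomeric groups. Set against 4-fluorophenyl, the same group gives a 56-fold lower number from compound 1 to compound 3 (1.74 log units; beyond the scatter) as its step. Nothing available accounts for the size of these steps. From the compounds shown here alone, whether both methyl groups are needed stays open, as does whether a methoxy group, an amine or a longer chain on this phenyl ring would keep the number this low.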